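A cyclobutyl alcohol on the amide chain

The source may report more compounds than this note shows. Statements on the series, on what has been measured and on what is new or still open speak of the compounds shown alone.

Compound 1 `Cc1ccc(C(F)(F)F)cc1Cn1c(C(=O)NCC(C)(C)CO)cc2cc(C#N)ccc21` reads 102 mL.min-1.g-1 in an in vitro ADME assay on microsomes from Gut (Homo sapiens) for metabolic stability, in the presence of a further agent that is not named here (on this read-out lower numbers stand for slow clearance and higher numbers for fast clearance), and compound 2 `CC(C)(O)CCNC(=O)c1cc2cc(C#N)ccc2n1Cc1cccc(OC(F)(F)F)c1` reads 9 mL.min-1.g-1 there. Compound 3 `N#Cc1ccc2c(c1)cc(C(=O)NCCC(O)C(F)(F)F)n2Cc1cccc(OC(F)(F)F)c1` reports only a limit of the assay, < 6 mL.min-1.g-1, not a number. Compound 4 `N#Cc1ccc2c(c1)cc(C(=O)NCCC1(O)CCC1)n2Cc1cccc(OC(F)(F)F)c1` carries 1-hydroxycyclobutyl in place of 2,2,2-trifluoro-1-hydroxyethyl on a saturated chain carbon, two bonds along the chain from an amide-type nitrogen. Among the measured compounds shown here, the one measured step at this place, an at least 1.5-fold lower number from compound 2 to compound 3 (0.17 log units; that floor lies within the scatter), has a floor within the scatter. Compound 2 carries 1-hydroxy-1-methylethyl and, like the entering group, no fluorine, so compound 4 is expected to read near it. A small rise in this assay is expected, a step of an at least 1.8-fold higher number from compound 3 to compound 4 (0.26 log units; that floor lies within the scatter) at this estimate. Compound 4 is estimated at 11 mL.min-1.g-1 (range 6 mL.min-1.g-1 to 28 mL.min-1.g-1).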

Compound 4, intrinsic clearance in microsomes: < 6 mL.min-1.g-1
Compound 4: no number, only a limit; the forecaster's own chance of this, stated with the estimate: 30%; middle value at least 1.8-fold (0.26 log units) away from the limit.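

In this assay compound 4 gives < 6 mL.min-1.g-1, a limit of the assay and not a number. Fluorine is therefore not needed for a chain alcohol at this place to read at the limit, since 1-hydroxycyclobutyl does so as well; the change from 1-hydroxy-1-methylethyl gives an at least 1.5-fold lower number from compound 2 to compound 4 (0.17 log units; that floor lies within the scatter). The step between the trifluorinated and the cyclobutyl alcohol cannot be read: the limit of < 6 mL.min-1.g-1 in this assay, at which 2 of the 4 values shown sit.

From the compounds shown here alone, how far compound 3 and compound 4 truly sit under that limit stays open. So does whether an amine in place of the hydroxyl on the cyclobutyl ring would read there too.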